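Chain Changes on the Double-Bonded Nitrogen: Dose in Rats

The source may hold more compounds than are shown below. What is called first, only, known or untested is meant among the compounds shown, and "the series" means these compounds.

Three compounds sharing one core were tested in a functional assay on the whole organism (blood, strain Wistar-Okamoto) with Rattus norvegicus as the target, with a stated time of 5 days; on this read-out lower numbers stand for an effect already at smaller amounts and higher numbers for an effect only at larger amounts of compound. Compound 1 `CC(C)C/N=C(\NC#N)Nc1cccnc1` gives 20 mg/kg in this assay. Compound 2 `CC(C)CC/N=C(\NC#N)Nc1cccnc1` differs from compound 1 by isobutyl in place of isopropyl on a saturated chain carbon bound to a double-bonded nitrogen; compound 2 gives 20 mg/kg, and the step of no change at the digits printed from compound 1 to compound 2 (within the scatter) shows that this lengthening left the read-out where it was. Compound 3 `CC(C)C(C)(C)/N=C(\NC#N)Nc1cccnc1` carries a different group on the same nitrogen, (1,1,2-trimethylpropyl in place of isobutyl on a double-bonded nitrogen), and gives 1 mg/kg. Here the step is large: a 20-fold lower number from compound 1 to compound 3 (1.30 log units; beyond the scatter), and likewise a 20-fold lower number from compound 2 to compound 3 (1.30 log units; beyond the scatter). Among the three, compound 3 is therefore the one that acts at the smallest amount, with both of its steps to the other compounds lying beyond the scatter.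

Compound 4 `CC(C)CC(C)(C)/N=C(\NC#N)Nc1cccnc1` has not yet been measured. It differs from compound 3 by isobutyl in place of isopropyl on a saturated chain carbon bound to a double-bonded nitrogen and two saturated chain carbons. For the measured compounds named here, this is the same kind of change as the one from compound 1 to compound 2, though not the same: in compound 1 the carbon that carries the change is bound only to the double-bonded nitrogen, whereas in compound 3 it is bound to the double-bonded nitrogen and two saturated chain carbons. Going by the values given here, the only measured example of this kind of change, no change at the digits printed from compound 1 to compound 2 (within the scatter), gave no shift. On that basis, the step from compound 3 to compound 4 is expected to be small, roughly no change at the digits printed from compound 3 to compound 4 (within the scatter), because no change at the digits printed from compound 1 to compound 2 (within the scatter) showed none. Compound 4 is accordingly estimated at 1 mg/kg in this assay, with a likely range from 0.4 mg/kg to 3 mg/kg.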

Compound 4, minimum effective dose: 2.5 mg/kg
Beside the measured number, compound 4's estimate is 2.5-fold (0.40 log units) below it; measured number inside the range.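

In this assay, isobutyl in place of isopropyl on a saturated chain carbon bound to a double-bonded nitrogen and two saturated chain carbons gave a 2.5-fold higher number from compound 3 to compound 4 (0.40 log units; beyond the scatter), a modest step that lies beyond the scatter when read alone. Set beside the earlier example of this change, however, it cannot be told apart from that step: the same change on two cores in this assay, no change at the digits printed (within the scatter) from compound 1 to compound 2 and a 2.5-fold higher number (0.40 log units; beyond the scatter) from compound 3 to compound 4, 2.5-fold (0.40 log units) apart, within the scatter of two such steps. This supports carrying the change from one core to the other without a detectable difference between the two steps, but it does not show that the steps are equal, and two pairs of compounds fix neither a general size for the change nor a reason for the movement seen only from compound 3 to compound 4.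

The compounds shown carry only branched saturated chains on the double-bonded nitrogen, so it remains open how a longer straight chain, a cyclohexyl group, or a chain ending in an amine or a carboxylic acid would read in this assay. On these data alone, it is also open whether the same change from isopropyl to isobutyl would give a comparable step on any further core.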